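The compounds below may be only part of what the source reports. "The series", "measured", "known", "first", "only" and "open" are said of these compounds alone.

Measured in a functional assay on CHO cells for antagonist activity at C-C chemokine receptor type 4 (Homo sapiens), read by GTPgammaS binding; on this read-out higher numbers stand for weaker inhibition and lower numbers for stronger inhibition:
compound 1 `CC(=O)NCc1cccc(Cn2nc(NS(=O)(=O)c3ccc(Cl)s3)c3ccccc32)c1` — 251 nM
compound 2 `COc1cccc2c1c(NS(=O)(=O)c1ccc(Cl)s1)nn2Cc1cccc(CNC(=O)C2CCCO2)c1` — 39.8 nM
compound 3 `COc1cccc2c1c(NS(=O)(=O)c1ccc(Cl)s1)nn2Cc1cccc(CNC(=O)C2CCOCC2)c1` — 31.6 nM

Compound 3 gives the lowest of the three numbers; compound 2 sits nearest, within the scatter, while compound 1, which lacks the methoxy group on the shared core and carries acetyl on the amide, stands well beyond it.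

Compound 4 `COc1cccc2c1c(NS(=O)(=O)c1ccc(Cl)s1)nn2Cc1cccc(CNC(=O)[C@@H]2CCCCN2)c1` differs from compound 3 by piperidin-2-yl in place of oxan-4-yl on a carbonyl carbon. Among the measured compounds shown here, the only measured step at this position, a 1.3-fold lower number from compound 2 to compound 3 (0.10 log units; within the scatter), exchanged one oxygen-containing ring for another and stayed within the scatter. For the measured compounds named here, no measured step introduces a ring nitrogen with a hydrogen-bond donor at the carbonyl carbon. In this assay compound 4 is therefore expected near compound 3, the estimated step of a 1.3-fold higher number from compound 3 to compound 4 (0.10 log units; within the scatter) lying within or near the scatter, with a wider range to allow for the untested change. Estimated: compound 4 40 nM, range 15 nM to 110 nM.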

Compound 4, half-maximal inhibitory concentration: 15.9 nM
Beside the measured number, compound 4's estimate is 2.5-fold (0.40 log units) above it; the measured number falls inside the stated range.
By their numbers in this assay, from the lowest: compounds 4, 3 and 2 (each within the scatter of the next, the first and the last beyond it); then compound 1.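

In this assay, piperidin-2-yl on the carbonyl carbon brings the first hydrogen-bond donor at this position, and no loss follows: a 2.0-fold lower number from compound 3 to compound 4 (0.30 log units; within the scatter), while a 2.5-fold lower number from compound 2 to compound 4 (0.40 log units; beyond the scatter). The carbonyl substituent therefore accepts a ring nitrogen in place of a ring oxygen, with only a modest separation from the oxolan-2-yl compound. No available evidence accounts for these steps.

As far as these compounds go, whether the ring nitrogen's placement or the defined stereocentre matters remains open. Piperidin-4-yl, the opposite stereoisomer and an open-chain amine would address this.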